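The source may hold more compounds than are shown below. What is called first, only, known or untested is meant among the compounds shown, and "the series" means these compounds.

Of the compounds shown here, three that share a core have been measured in a functional assay on K562 cells (Homo sapiens) for inhibition, read by fluorescence, with a stated time of 72 h; a lower number here means a stronger inhibitor of growth, a higher number a weaker inhibitor of growth. Compound 1 (`CCCCn1cnc2c(NCc3cccc(Cl)c3)nc(N[C@H]3CC[C@H](N)CC3)nc21`) gives 4300 nM, compound 2 (`COc1cc(Nc2nc(N[C@H]3CC[C@H](N)CC3)nc3c2ncn3CCC(C)C)cc(OC)c1`) gives 2500 nM, and compound 3 (`CCCCCCn1cnc2c(Nc3cc(OC)cc(OC)c3)nc(N[C@H]3CC[C@H](N)CC3)nc21`) gives 1900 nM. Compound 3 therefore stands well clear of compound 1, whose number is the higher of the two, but it cannot be separated from compound 2.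

The next compound, compound 4 (`CCCCn1cnc2c(Nc3cc(OC)cc(OC)c3)nc(N[C@H]3CC[C@H](N)CC3)nc21`), keeps everything in compound 3 except the end of the chain on the aromatic nitrogen: hydrogen in place of ethyl on a saturated chain carbon, four bonds along the chain from an aromatic nitrogen. In words, this is hydrogen in place of ethyl on a saturated chain carbon, four bonds along the chain from an aromatic nitrogen.

Among the compounds with values here, only one measured step bears on this chain, a 1.3-fold lower number from compound 2 to compound 3 (0.12 log units; within the scatter). It places butyl in place of isopropyl on a saturated chain carbon, two bonds along the chain from an aromatic nitrogen. That change is a different one, so it is only a rough guide, but it suggests that altering this chain moves the number little. Within the data shown here, no measured step connects compound 1 to the others.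

The expectation is therefore a 1.3-fold higher number from compound 3 to compound 4 (0.10 log units; within the scatter), a possible slight rise that stays inside the scatter. For compound 4 the estimated value is 2400 nM, with an expected range from 1200 nM to 4600 nM.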

Compound 4, concentration for 50% growth inhibition: 2400 nM
The estimate for compound 4 equals the measured number at the digits printed; low and high end bracket the measured number.
By their numbers in this assay, from the lowest: compounds 3, 4, 2 and 1 (each within the scatter of the next, the first and the last beyond it).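

Putting hydrogen in place of ethyl on a saturated chain carbon, four bonds along the chain from an aromatic nitrogen, gives a 1.3-fold higher number from compound 3 to compound 4 (0.10 log units; within the scatter) in this assay and shows directly that this end of the chain can be cut back with no change that can be told from the scatter. The other two new comparisons agree: hydrogen in place of methyl on a saturated chain carbon bound to two saturated chain carbons gives a 1.0-fold lower number from compound 2 to compound 4 (0.02 log units; within the scatter) and 3,5-dimethoxyphenyl in place of 3-chlorobenzyl on a nitrogen on an aromatic ring gives a 1.8-fold lower number from compound 1 to compound 4 (0.25 log units; within the scatter) so neither the branch on the chain nor this exchange on the ring nitrogen separates the compounds. Nothing is available here that explains why these numbers stay so close.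

Going by these compounds, every chain on the aromatic nitrogen in these compounds is made only of carbon and hydrogen, so it remains open whether an amine or a carboxylic acid at the chain end, or a chain longer than any of these, would move the number beyond the scatter. On these data alone, it also remains open whether a pyridine ring on the other nitrogen would do so.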